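A few compounds are considered here, and "the series" means these few. Any claim that something is new, unique, unknown or untested is made for them only; others in the source may bear on it.

In a functional assay on MCF7 cells (Homo sapiens) for inhibition, read by sulforhodamine B assay, with a stated time of 48 h, tested at 50 uM (on this read-out higher numbers stand for more inhibition of growth at the one concentration tested and lower numbers for less inhibition of growth), compound 1 `COc1cc2c(cc1CC=C(C)C)C(=O)C[C@@H](c1ccc(Oc3ccc(F)cc3)cc1)O2` gives 37% and compound 3 `CC(C)=CCc1cc2c(cc1O)O[C@H](c1ccc(O)cc1)CC2=O` gives 99%. Compound 2 `COc1ccc([C@@H]2C/C(=N/OCc3cn(-c4ccccc4CO)nn3)c3cc(CC=C(C)C)c(OC)cc3O2)cc1` gives 100%, which is within the scatter of the value of compound 3 and beyond the scatter above that of compound 1. Compound 4 `COc1ccc([C@@H]2C/C(=N/OCc3cn(-c4cccnc4Cl)nn3)c3cc(CC=C(C)C)c(OC)cc3O2)cc1` carries 2-chloropyridin-3-yl in place of the 2-(hydroxymethyl)phenyl of compound 2, on an aromatic nitrogen of a five-membered aromatic ring with 3 nitrogen (2-chloropyridin-3-yl in place of 2-(hydroxymethyl)phenyl on an aromatic nitrogen). For the measured compounds named here, no measured pair shows this change alone. In this assay an upward step has little room because compound 2 gives 100%, so a moderate fall is expected. The estimated size of this fall is a number 20 percentage points lower from compound 2 to compound 4 (beyond the scatter). Compound 4 is expected at 80%, within an estimated range of 50% to 100%.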

Compound 4, percent growth inhibition at one concentration: 35%
Compound 4: the middle estimate sits 45 percentage points above what was measured; measured number outside the range, below it.
By their numbers in this assay, from the lowest: compounds 4 and 1 (each within the scatter of the next); then compounds 3 and 2 (each within the scatter of the next).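

In this assay, the group on the aromatic nitrogen of the five-membered ring proves decisive: 2-chloropyridin-3-yl in place of 2-(hydroxymethyl)phenyl gives a number 65 percentage points lower from compound 2 to compound 4 (beyond the scatter), a large step. The high inhibition of compound 2 therefore does not survive this exchange, in which the hydrogen-bond donor count of the group falls from one to none. Nothing measured here explains the fall. The compounds shown leave open whether the hydroxymethyl, the ring nitrogen or the chlorine carries the step. An aminomethyl or a carboxylic acid in place of the hydroxymethyl remains an open case.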